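Compound 3 to Compound 4: One Chlorine Moves

The source may hold more compounds than are shown below. What is called first, only, known or untested is meant among the compounds shown, and "the series" means these compounds.

Compound 1, `O=C(Nc1cc(C(F)(F)F)cc(C(F)(F)F)c1)C1CCc2ccccc2N1C(=O)c1ccc(Cl)cc1`: 2220 nM
Compound 2, `CC(=O)N1c2ccccc2CCC1C(=O)Nc1cc(C(F)(F)F)cc(C(F)(F)F)c1`: > 70000 nM (a limit, not a number)
Compound 3, `O=C(Nc1cc(C(F)(F)F)cc(C(F)(F)F)c1)C1CCc2ccccc2N1C(=O)c1cccc(Cl)c1`: 625 nM

All three were tested in a functional assay on HCT-15 cells (Homo sapiens) for cytotoxicity, read by sulforhodamine B assay, with a stated time of 72 h; a lower number here means a stronger inhibitor of growth, a higher number a weaker inhibitor of growth. Compound 3 gives the lowest of the two numbers shown; the step of a 3.6-fold lower number from compound 1 to compound 3 (0.55 log units; beyond the scatter) is modest. Compound 2 reaches only the limit (the limit of > 70000 nM in this assay, at which 1 of the 3 values shown sits). The steps of an at least 31-fold higher number from compound 1 to compound 2 (1.49 log units; beyond the scatter) and an at least 110-fold lower number from compound 2 to compound 3 (2.04 log units; beyond the scatter) are large. Compound 4, `O=C(Nc1cc(C(F)(F)F)cc(C(F)(F)F)c1)C1CCc2ccccc2N1C(=O)c1ccccc1Cl`, differs from compound 3 by 2-chlorophenyl in place of 3-chlorophenyl on a carbonyl carbon. For the measured compounds named here, the only measured step that touches this part of the molecule is a 3.6-fold lower number from compound 1 to compound 3 (0.55 log units; beyond the scatter), so a modest step in this assay is expected for compound 4, with the direction uncertain. Compound 4 is therefore estimated at 1500 nM, with a range from 300 nM to 8000 nM, which is expected to mean a 2.4-fold higher number from compound 3 to compound 4 (0.38 log units; beyond the scatter).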

Compound 4, concentration for 50% growth inhibition: 4050 nM
Compound 4: middle estimate off by 2.7-fold (0.43 log units), on the low side, within the range that was stated.
By their numbers in this assay, from the lowest: compound 3; then compounds 1 and 4 (each within the scatter of the next). At a limit, above all of these: compound 2.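

In this assay the place of the chlorine alone changes the result, with a 6.5-fold higher number from compound 3 to compound 4 (0.81 log units; beyond the scatter) for 2-chlorophenyl in place of 3-chlorophenyl, while a 1.8-fold higher number from compound 1 to compound 4 (0.26 log units; within the scatter) leaves 2-chlorophenyl and 4-chlorophenyl not told apart. Replacing methyl with 2-chlorophenyl still gives an at least 17-fold lower number from compound 2 to compound 4 (1.23 log units; beyond the scatter) as a large step. That step rests on compound 2, whose value is a limit and not a number: the limit of > 70000 nM in this assay, at which 1 of the 4 values shown sits.

Open, going by these compounds, is whether a methoxy group, a nitrile or an amine in place of the chlorine on the phenyl ring would match 3-chlorophenyl. On these data alone, whether an unsubstituted phenyl would do so also remains open.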